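The source may report more compounds than this note shows. Statements on the series, on what has been measured and on what is new or still open speak of the compounds shown alone.

In a functional assay on U-937 cells (Homo sapiens) (on this read-out lower numbers stand for stronger inhibition and higher numbers for weaker inhibition), three compounds sharing one core have been measured. Compound 1 `COc1cc(C(=O)NS(=O)(=O)c2ccccc2C)ccc1Cc1cn(C(F)F)c2ccc(NC(=O)OC3CCCC3)cc12` gives 0.4 nM, compound 2 `COc1cc(C(=O)NS(=O)(=O)c2ccccc2C)ccc1Cc1cn(C(=O)NCCCc2ccccc2)c2ccc(NC(=O)OC3CCCC3)cc12` gives 0.1 nM, and compound 3 `COc1cc(C(=O)NS(=O)(=O)c2ccccc2C)ccc1Cc1cn(C(=O)N2CCOCC2)c2ccc(NC(=O)OC3CCCC3)cc12` gives 2 nM, the highest of the three numbers. Compound 4 `COc1cc(C(=O)NS(=O)(=O)c2ccccc2C)ccc1Cc1cn(C(=O)NCCN(C)C)c2ccc(NC(=O)OC3CCCC3)cc12` differs from compound 3 by one change: (2-(dimethylamino)ethyl)amino in place of morpholin-4-yl on a carbonyl carbon. Going by the values given here, the closest precedent is the large step of a 20-fold higher number from compound 2 to compound 3 (1.30 log units; beyond the scatter), made at that same carbonyl carbon. The modest steps of a 4.0-fold lower number from compound 1 to compound 2 (0.60 log units; beyond the scatter) and a 5.0-fold higher number from compound 1 to compound 3 (0.70 log units; beyond the scatter) show both carbonyl compounds departing from the difluoromethyl compound in opposite directions. Like compound 2, compound 4 carries an amino group without a ring there, though its chain is different, so only part of that large step is expected to return. The expected step in this assay is modest, a 4.0-fold lower number from compound 3 to compound 4 (0.60 log units; beyond the scatter), toward a lower number. For compound 4 the estimated value is 0.5 nM, with an expected range of 0.1 nM to 2 nM.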

Compound 4, half-maximal inhibitory concentration: 0.1 nM
Compound 4: the middle estimate sits 5.0-fold (0.70 log units) above what was measured; the range from low to high includes it.
By their numbers in this assay, from the lowest: compounds 2 and 4 (each within the scatter of the next); then compound 1; then compound 3.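

Putting (2-(dimethylamino)ethyl)amino in place of morpholin-4-yl on the carbonyl carbon gives a 20-fold lower number from compound 3 to compound 4 (1.30 log units; beyond the scatter), so the low numbers at this position are not confined to the (3-phenylpropyl)amino group of compound 2. The end of the chain makes no visible difference here, with dimethylamino in place of benzyl giving no change at the digits printed from compound 2 to compound 4 (within the scatter). Against the difluoromethyl compound, the new chain gives a 4.0-fold lower number from compound 1 to compound 4 (0.60 log units; beyond the scatter). Nothing shown offers a reason for these steps. In these compounds the ring and the amide hydrogen change together; a dimethylamino group on that carbonyl carbon would part them.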